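The compounds below may be only part of what the source reports. "The series", "measured", "known", "first", "only" and "open" are said of these compounds alone.

Of the compounds shown here, three that share one core have been measured in a functional assay on M14 cells (Homo sapiens) for inhibition, read by sulforhodamine B assay, with a stated time of 48 h; on this read-out lower numbers stand for stronger inhibition of growth and higher numbers for weaker inhibition of growth. Compound 1 `COc1cc(-c2cc(/C=C/C(=O)c3ccc(N)cc3)[nH]n2)cc(OC)c1OC` gives 1830 nM in this assay. Compound 2 `COc1cc(-c2cc(/C=C/C(=O)c3ccc(Cl)c(Cl)c3)[nH]n2)cc(OC)c1OC` gives 18200 nM. Compound 3 `COc1ccc(C(=O)/C=C/c2cc(-c3cc(OC)c(OC)c(OC)c3)n[nH]2)cc1` gives 2200 nM, which places it second highest of the three numbers: its gap to compound 1 lies within the scatter, while compound 2 sits well above it. The measured steps show that the group on the carbonyl carbon matters: a 9.9-fold higher number from compound 1 to compound 2 (1.00 log units; beyond the scatter), and an 8.3-fold lower number from compound 2 to compound 3 (0.92 log units; beyond the scatter), whereas a 1.2-fold higher number from compound 1 to compound 3 (0.08 log units; within the scatter).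

Compound 4 `COc1cc(-c2cc(/C=C/C(=O)c3ccc(F)c(F)c3)[nH]n2)cc(OC)c1OC` has not yet been measured. It differs from compound 3 in one place: 3,4-difluorophenyl in place of 4-methoxyphenyl on a carbonyl carbon. The closest guide is the step from compound 2 to compound 3, in which a 3,4-dichlorophenyl was exchanged for a 4-methoxyphenyl and the number fell markedly. Compound 4 reverses that kind of exchange, with fluorine in place of chlorine, so the expectation is a clearly higher number, though not necessarily as high as that of compound 2. The expected step is a 4.1-fold higher number from compound 3 to compound 4 (0.61 log units; beyond the scatter). Compound 4 is therefore estimated at 9000 nM in this assay, with a range from 3000 nM to 25000 nM.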

Compound 4, concentration for 50% growth inhibition: 2700 nM
The estimate for compound 4 lay 3.3-fold (0.52 log units) above the measured number; the whole stated range lies above it.
By their numbers in this assay, from the lowest: compounds 1, 3 and 4 (each within the scatter of the next); then compound 2.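

In this assay, the 3,4-difluorophenyl on the carbonyl carbon gives a number that cannot be told apart from that of the 4-methoxyphenyl (a 1.2-fold higher number from compound 3 to compound 4 (0.09 log units; within the scatter)) or the 4-aminophenyl (a 1.5-fold higher number from compound 1 to compound 4 (0.17 log units; within the scatter)), so these three quite different rings all fit within the scatter, even though the hydrogen-bond acceptor counted on the 4-methoxyphenyl is absent from the 3,4-difluorophenyl. The weak result for compound 2 therefore cannot be read as a penalty for any ring with two halogens, since the exchange of 3,4-dichlorophenyl for 3,4-difluorophenyl alone gives a clear drop (a 6.7-fold lower number from compound 2 to compound 4 (0.83 log units; beyond the scatter)), which leaves compound 2 as the only one of the four standing apart. Nothing available here explains why the chlorine and fluorine compounds differ.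

The compounds shown leave open whether a ring carrying a single chlorine would sit with compound 2 or with the other three. They also leave open how a trifluoromethyl group, a nitrile or a carboxylic acid on this ring would compare.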